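A few compounds are considered here, and "the series" means these few. Any claim that something is new, unique, unknown or untested is made for them only; others in the source may bear on it.

In a functional assay on MCF7 cells (Homo sapiens) for inhibition, read by sulforhodamine B assay, with a stated time of 48 h (a higher number here means a weaker inhibitor of growth, a lower number a stronger inhibitor of growth), compound 3 (`Cc1ccc(NC2=NCCO2)cc1`) gives 27000 nM and sits within the scatter of compound 1 (`c1cc(C2CCCCC2)ccc1NC1=NCCO1`) at 17500 nM while compound 2 (`CC(C)(C)c1ccc(NC2=NCCO2)cc1`) gives the lowest number at 3000 nM in this set. Compound 4 (`Cc1ccc(NC2=NCCO2)cc1C`) differs from compound 3 by methyl in place of hydrogen on an aromatic carbon is the whole change. Among the compounds with values here, no measured step adds a group at that place. Only swaps of the existing group bear on it: a 1.5-fold higher number from compound 1 to compound 3 (0.19 log units; within the scatter) lies within the scatter and a 9.0-fold higher number from compound 2 to compound 3 (0.95 log units; beyond the scatter) lies beyond it, so these steps give no single trend. The step expected in this assay is small and towards a lower number, with a 1.6-fold lower number from compound 3 to compound 4 (0.20 log units; within the scatter) as the estimate. Compound 4 is estimated at 17000 nM with 6500 nM to 40000 nM as the expected range.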

Compound 4, concentration for 50% growth inhibition: 5700 nM
Beside the measured number, compound 4's estimate is 3.0-fold (0.47 log units) above it; measured number outside the range, below it.
By their numbers in this assay, from the lowest: compounds 2 and 4 (each within the scatter of the next); then compounds 1 and 3 (each within the scatter of the next).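

In this assay the added methyl gives a 4.7-fold lower number from compound 3 to compound 4 (0.68 log units; beyond the scatter) and so shows that this aromatic carbon, ortho to a methyl group and meta to a group of 6 heavy atoms, responds to substitution. The earlier steps shown here only swapped the existing group and could not show this. No measurement on hand accounts for the step.

Still open, from the compounds shown here alone, is whether a chlorine, a methoxy group or an amine at this carbon gives a step of similar size. Also open, going by these compounds, is whether an added methyl lowers the number likewise in compound 2.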